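The source may report more compounds than this note shows. Statements on the series, on what has been measured and on what is new or still open speak of the compounds shown alone.

Of the compounds shown here, three built on one shared core have been tested in a functional assay on CV-1 cells for agonist activity at Bile acid receptor (Homo sapiens), read by a luciferase reporter; on this read-out lower numbers stand for an effect already at smaller amounts and higher numbers for an effect only at larger amounts of compound. Compound 1 `CC(C)c1onc(-c2c(Cl)cccc2Cl)c1COc1ccc(-c2ccc3c(C(=O)O)ccnc3c2)cc1` gives 560 nM. Compound 2 `CC(C)c1onc(-c2c(Cl)cccc2Cl)c1COc1ccc(-c2ccc3nc(C(=O)O)cnc3c2)cc1` gives 690 nM. Compound 3 `CC(C)c1onc(-c2c(Cl)cccc2Cl)c1COc1ccc(-c2ccc3nc(C(=O)O)cc(O)c3c2)cc1`, which carries a hydroxy group on its core, gives 10000 nM, the highest of the three numbers; its gaps to compound 2 and to compound 1 both lie beyond the usual scatter, so compound 3 is the weakest of the measured set. Compound 4 `CC(C)COc1cc(C(=O)O)nc2ccc(-c3ccc(OCc4c(-c5c(Cl)cccc5Cl)noc4C(C)C)cc3)cc12` has not yet been measured. It differs from compound 3 in one place: isobutyl in place of hydrogen on an oxygen on an aromatic ring. Within the data shown here, no pair of measured compounds shows this step, so its size is open. The two compounds without the hydroxy group, compound 1 and compound 2, give lower numbers than compound 3, and replacing the hydrogen on that oxygen with isobutyl is expected to move the number in the same direction, though how far is uncertain. The change from compound 3 to compound 4 is estimated as a 4.0-fold lower number from compound 3 to compound 4 (0.60 log units; beyond the scatter) in this assay. Compound 4 is therefore expected to give about 2500 nM, within a range from 600 nM to 10000 nM.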

Compound 4, half-maximal effective concentration: 81 nM
Estimate against measurement, compound 4: 31-fold (1.49 log units) above; measured number outside the range, below it.
By their numbers in this assay, from the lowest: compound 4; then compounds 1 and 2 (each within the scatter of the next); then compound 3.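

Capping the oxygen on the aromatic ring, hydroxy to isobutoxy, gives a 120-fold lower number from compound 3 to compound 4 (2.09 log units; beyond the scatter) in this assay, and this large step is the first in the set that isolates a single change. Among these compounds, the earlier compounds showed only that the hydroxy compound stood highest, whereas this step shows that the oxygen can carry a branched chain and that what sits on it strongly moves the number. Nothing at hand explains why this change has so large an effect.

Only hydrogen and isobutyl are shown on this oxygen, so it remains open whether a small methyl, a straight butyl chain or a benzyl group would give a similar number. Also open, from the compounds shown here alone, is whether an amine in place of the oxygen would keep this gain.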